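Removing one chloro group on a fused pyrimidine core

This account rests on a few compounds, and the source may have more. Where it says the series, first, only, none or still open, it means among the compounds named here.

Measured so far in a functional assay on U-251 cells (Homo sapiens) for cytotoxicity, read by sulforhodamine B assay, with a stated time of 48 h; on this read-out lower numbers stand for stronger inhibition of growth and higher numbers for weaker inhibition of growth:
- compound 1 `ClCc1cccc(Cn2cnc3c(Cl)ncnc32)c1` gives 3460 nM
- compound 2 `ClCc1ccc(Cn2cnc3nc(Cl)nc(Cl)c32)cc1` gives 3230 nM
- compound 3 `ClCc1cccc(Cn2cnc3c(Cl)nc(Cl)nc32)c1` gives 3090 nM

All three compounds sit close together; no one of them stands apart from the others beyond the usual scatter. Compound 3 and compound 1 differ in a single place, (hydrogen in place of chloro on an aromatic carbon), and this step gives a 1.1-fold higher number from compound 3 to compound 1 (0.05 log units; within the scatter). Compound 2 carries the same atoms as compound 3 but joined differently; the difference between the two cores is not broken down here.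

Compound 4 `ClCc1ccc(Cn2cnc3ncnc(Cl)c32)cc1` has not been measured. It is related to compound 2 by hydrogen in place of chloro on an aromatic carbon, which is the same change that turns compound 3 into compound 1. Because that earlier step gave a 1.1-fold higher number from compound 3 to compound 1 (0.05 log units; within the scatter), the step from compound 2 to compound 4 is expected to be of similar size, a 1.1-fold higher number from compound 2 to compound 4 (0.03 log units; within the scatter). On that basis compound 4 is estimated to give about 3500 nM in this assay, with a plausible range from 1800 nM to 7000 nM.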

Compound 4, concentration for total growth inhibition: 2290 nM
The estimate for compound 4 lay 1.5-fold (0.18 log units) above the measured number, within the range that was stated.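

In this assay, putting hydrogen in place of the chloro group on the second core gives a 1.4-fold lower number from compound 2 to compound 4 (0.15 log units; within the scatter), so here too the change leaves the number inside the usual scatter. Set beside the first case, the two steps agree as closely as repeated measurements allow: the same change on two cores in this assay, a 1.1-fold higher number (0.05 log units; within the scatter) from compound 3 to compound 1 and a 1.4-fold lower number (0.15 log units; within the scatter) from compound 2 to compound 4, 1.6-fold (0.20 log units) apart, within the scatter of two such steps. In these two pairs the change therefore carries from one core to the other without a difference that can be told from scatter, but this does not show that it would behave alike on other cores, and two small steps cannot reveal whether a real but slight effect lies hidden within the scatter.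

It remains open whether an amine or a methoxy group on that same aromatic carbon, between two ring nitrogen atoms, would give a number outside the scatter of these compounds. Going by these compounds, it is also open whether the step would stay this small with a plain methyl group in place of the chloromethyl group, or with an amine in place of the remaining chloro group.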